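A few compounds are considered here, and "the series" means these few. Any claim that something is new, unique, unknown or untested is made for them only; others in the source may bear on it.

Three compounds have been measured in a functional assay on HT-29 cells (Homo sapiens) for inhibition, read by MTT assay, with a stated time of 48 h; a higher number here means a weaker inhibitor, a lower number a stronger inhibitor:

Compound 1 `Cc1ccc(NC(=S)NC(=O)c2ccc(OCc3cccc(Cl)c3)cc2)cc1-c1nc2ccccc2[nH]1`: 35300 nM
Compound 2 `Cc1ccc(NC(=S)NC(=O)c2ccc(OCc3ccccc3F)cc2)cc1-c1nc2ccccc2[nH]1`: 1870 nM
Compound 3 `Cc1ccc(NC(=S)NC(=O)c2ccc(OCc3cccc(Cl)c3Cl)cc2)cc1-c1nc2ccccc2[nH]1`: 63700 nM

Of these three, compound 3 gives the highest number, so it is the weakest inhibitor of the set. Its nearest neighbour is compound 1: the step of a 1.8-fold higher number from compound 1 to compound 3 (0.26 log units; within the scatter) lies within the scatter of the assay. Its most distant neighbour is compound 2: the step of a 34-fold higher number from compound 2 to compound 3 (1.53 log units; beyond the scatter) is large and well beyond the scatter.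

Compound 4 `Cc1ccc(NC(=S)NC(=O)c2ccc(OCc3ccccc3Cl)cc2)cc1-c1nc2ccccc2[nH]1` is the next compound to be measured. It differs from compound 3 in one place: hydrogen in place of chloro on an aromatic carbon.

Going by the values given here, two measured steps bear on this change. The step of a 1.8-fold higher number from compound 1 to compound 3 (0.26 log units; within the scatter) shows that putting this same chloro onto a chlorophenyl ring changed little, which on its own would suggest that taking it off changes little too. On the other hand, the step of a 34-fold higher number from compound 2 to compound 3 (1.53 log units; beyond the scatter) shows that a single small halogen at this end of the molecule goes with a much lower number, and compound 4 keeps a single halogen there, so it stands structurally between compound 2 and compound 3. The expected outcome is therefore a moderate move toward a lower number, a 5.3-fold lower number from compound 3 to compound 4 (0.72 log units; beyond the scatter), though with wide uncertainty. Compound 4 is estimated at 12000 nM, with a range from 2500 nM to 50000 nM.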

Compound 4, half-maximal inhibitory concentration: 23700 nM
The estimate for compound 4 lay 2.0-fold (0.30 log units) below the measured number, within the range that was stated.
By their numbers in this assay, from the lowest: compound 2; then compounds 4, 1 and 3 (each within the scatter of the next, the first and the last beyond it).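

In this assay, taking away one chloro to turn 2,3-dichlorobenzyl into 2-chlorobenzyl gives a 2.7-fold lower number from compound 3 to compound 4 (0.43 log units; beyond the scatter), a modest step that lies beyond the scatter, so this change does register, though only slightly. The sharper finding comes from changing the halogen while leaving its place on the ring the same: chloro in place of fluoro gives a 13-fold higher number from compound 2 to compound 4 (1.10 log units; beyond the scatter), a large step and far bigger than the one from removing the chloro. Moving the single chloro, with 2-chlorophenyl in place of 3-chlorophenyl, gives a 1.5-fold lower number from compound 1 to compound 4 (0.17 log units; within the scatter), which is within the scatter, so the low number of compound 2 goes with fluoro specifically and not simply with having one halogen on this ring.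

No measurement shown here accounts for the gap between fluoro and chloro on this ring. As far as these compounds go, it remains open whether bromo, methoxy or a plain hydrogen on that same aromatic carbon would give a number close to that of compound 2 or close to that of compound 4.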